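Methyl capping of the phenol in a bicyclic lactam triazole series

The source may report more compounds than this note shows. Statements on the series, on what has been measured and on what is new or still open speak of the compounds shown alone.

Measured compounds:
Compound 1 `CC1(C)[C@H]2CC[C@]1(C)N(Cc1cn(-c3ccccc3F)nn1)C(=O)C2` gives 300 nM.
Compound 2 `CC1(C)[C@H]2CC[C@]1(C)N(Cc1cn(-c3ccc(O)cc3)nn1)C(=O)C2` gives 410 nM.

Within the data shown here, in a functional assay on OVCAR-3 cells (Homo sapiens) for inhibition, read by MTT assay, with a stated time of 24 h (a higher number here means a weaker inhibitor, a lower number a stronger inhibitor), compound 2 stands at the higher of the two numbers so far, and its nearest neighbour is compound 1, with a 1.4-fold higher number from compound 1 to compound 2 (0.14 log units; within the scatter). Compound 3 `COc1ccc(-n2cc(CN3C(=O)C[C@@H]4CC[C@@]3(C)C4(C)C)nn2)cc1` has not yet been tested. It differs from compound 2 by methyl in place of hydrogen on an oxygen on an aromatic ring. Among the measured compounds shown here, the only measured step, from compound 1 to compound 2, changes a different part of the molecule and stays within the scatter, so nothing in the data speaks directly to replacing the hydrogen on the oxygen by a methyl. For the measured compounds named here, with no step of this kind to draw on, the expectation for compound 3 is a number close to that of compound 2, and the expected step of a 1.1-fold higher number from compound 2 to compound 3 (0.04 log units; within the scatter) is one of no change beyond the scatter. Compound 3 is therefore estimated at 450 nM in this assay, with a range of 180 nM to 1100 nM.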

Compound 3, half-maximal inhibitory concentration: 250 nM
Estimate against measurement, compound 3: 1.8-fold (0.26 log units) above, within the range that was stated.
By their numbers in this assay, from the lowest: compounds 3, 1 and 2 (each within the scatter of the next).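

In this assay, among these compounds, the change from 4-hydroxyphenyl to 4-methoxyphenyl, with methyl in place of hydrogen on the oxygen, gives a 1.6-fold lower number from compound 2 to compound 3 (0.21 log units; within the scatter) and thus offers the first direct reading at this oxygen: capping it produces no shift that can be told from the scatter. Putting 4-methoxyphenyl in place of 2-fluorophenyl on the aromatic nitrogen gives a 1.2-fold lower number from compound 1 to compound 3 (0.08 log units; within the scatter) and so leaves all three aryl groups shown within the scatter of one another, which means the hydrogen on this oxygen is not needed for a value of this order. Nothing among the data given offers an explanation for this result.

As far as these compounds go, whether an ethoxy or benzyloxy group on this oxygen, or an amine or a carboxylic acid in place of the hydroxy group, would move the number beyond the scatter stays open. From the compounds shown here alone, all three compounds also share one core, so the effect of changing it remains unknown.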